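A few compounds are considered here, and "the series" means these few. Any claim that something is new, unique, unknown or untested is made for them only; others in the source may bear on it.

Measured in an ADME assay on BJ cells (Homo sapiens) for cytotoxicity, read by CellTiter-Glo and resazurin assay, with a stated time of 72 h; a higher number here means that more compound is needed for the effect, a lower number that less compound is needed:

compound 1 `CC(C)N(Cc1cccc(OCCCCCC(=O)O)c1)C(=O)c1ccc(-c2cccc(O)c2)cc1`: > 26000 nM
compound 2 `CC(C)N(Cc1cccc(OCCCCCC(=O)O)c1)C(=O)c1ccc(-c2cccc(OC(F)(F)F)c2)cc1`: > 26000 nM
compound 3 `CCOC(=O)CCCCCOc1cccc(CN(C(=O)c2ccc(-c3cccc(O)c3)cc2)C(C)C)c1`: > 26000 nM

Each of these three values is a limit of the assay, not a number. For compound 1 the value > 26000 nM is a limit. For compound 2 the value > 26000 nM is a limit. For compound 3 the value > 26000 nM is a limit.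

The change from compound 1 to compound 2 is trifluoromethyl in place of hydrogen on an oxygen on an aromatic ring. In this assay it gives a step that the two limits leave unreadable from compound 1 to compound 2. The cores of compound 1 and compound 3 differ by ethyl in place of hydrogen on an oxygen next to a carbonyl group, and that step reads a step that the two limits leave unreadable from compound 1 to compound 3.

Compound 4 `CCOC(=O)CCCCCOc1cccc(CN(C(=O)c2ccc(-c3cccc(OC(F)(F)F)c3)cc2)C(C)C)c1` has not been measured. It differs from compound 3 by trifluoromethyl in place of hydrogen on an oxygen on an aromatic ring. This is the same change as from compound 1 to compound 2, at the same place, on an oxygen on an aromatic ring whose other neighbours are aromatic carbon. The size of that change is not readable, because of the limit of > 26000 nM in this assay, at which 3 of the 3 values shown sit. Nothing among the three measured compounds shows any readable movement in this assay.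

For compound 4 the expected step is a step that the limit leaves unreadable from compound 3 to compound 4, that is, no readable change from compound 3. Compound 4 is estimated at 30000 nM in this assay, with a range from 15000 nM to 80000 nM, and most likely the assay will again report only a limit.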

Compound 4, half-maximal effective concentration: > 26000 nM
Compound 4: only a limit was reported; the forecaster's own chance of this, stated with the estimate: 85%; the middle value is on the limit's open side.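

In this assay compound 4 gives > 26000 nM, a limit and not a number. For the compounds shown here, no step from compound 3 or compound 2 to compound 4 can be read, because all the values share one limit: the limit of > 26000 nM in this assay, at which 4 of the 4 values shown sit. The compounds shown leave open whether either change, hydroxy to trifluoromethoxy or ethyl in place of hydrogen on the acid oxygen, has any effect in this assay.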